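The source may report more compounds than this note shows. Statements on the series, on what has been measured and on what is new or still open speak of the compounds shown alone.

Values in a functional assay on MCF7 cells (Homo sapiens) for antiproliferative activity, read by CellTiter-Glo, with a stated time of 5 days; a higher number here means a weaker inhibitor, a lower number a stronger inhibitor:
- Compound 1 `CC/C(=C(/c1ccc(/C=C/C(=O)O)cc1)c1ccc2c(cnn2C)c1)c1ccc(F)cc1Cl`: 81 nM
- Compound 2 `CC/C(=C(/c1ccc(/C=C/C(=O)O)cc1)c1ccc2c(cnn2C)c1)c1ccccc1`: 300 nM
- Compound 3 `CC/C(=C(/c1ccc(/C=C/C(=O)O)cc1)c1ccc2cncn2c1)c1ccccc1`: > 500 nM

Compound 3 sits at the limit of > 500 nM in this assay, at which 1 of the 3 values shown sits. Its true value is therefore not known as a number, and any comparison with it is loose.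

Compound 4 `CC/C(=C(/c1ccc(/C=C/C(=O)O)cc1)c1ccc2nnnn2c1)c1ccccc1` is not yet measured. It differs from compound 3 in one place, on a double-bonded chain carbon bound to an aromatic carbon and a double-bonded chain carbon: a group of 9 heavy atoms (5 carbon, 4 nitrogen; one five-membered aromatic ring with 4 hetero atoms, one six-membered aromatic ring with 1 hetero atom) in place of a group of 9 heavy atoms (7 carbon, 2 nitrogen; one five-membered aromatic ring with 2 hetero atoms, one six-membered aromatic ring with 1 hetero atom), on a double-bonded chain carbon bound to an aromatic carbon and a double-bonded chain carbon.

The step that bears most directly on this is the earlier change at that same place, an at least 1.6-fold higher number from compound 2 to compound 3 (0.22 log units; that floor lies within the scatter). It is only a floor and does not clearly exceed the usual scatter. The other measured step, a 3.7-fold higher number from compound 1 to compound 2 (0.57 log units; beyond the scatter), lies at a different place. Among the compounds with values here, it shows only that a single change can move the number modestly.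

A small step is therefore expected in this assay, most likely with no change beyond the scatter and a slight lean toward a higher number. The expected change is a step that the limit leaves unreadable from compound 3 to compound 4, which is a rough guide. In this assay the estimate for compound 4 is 700 nM, with an expected range from 250 nM to 2500 nM.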

Compound 4, half-maximal inhibitory concentration: > 500 nM
Compound 4: a limit, no number; the forecaster's own chance of this, stated with the estimate: 60%; the middle value lies beyond the limit too.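

In this assay, the group with 4 hetero atoms in its five-membered aromatic ring leaves compound 4 reported only as a limit, as compound 3 is, so the step between these two compounds cannot be read. Measured against the group with a six-membered aromatic ring of carbon only, this change gives an at least 1.6-fold higher number from compound 2 to compound 4 (0.22 log units; that floor lies within the scatter), a floor that says little on its own about the true size of the step. What is new is that a second group with a six-membered aromatic ring with 1 hetero atom, this one carrying 4 hetero atoms in the five-membered ring and not 2, also gives no readable number at this place: the limit of > 500 nM in this assay, at which 2 of the 4 values shown sit.

How far compound 3 and compound 4 each lie past the limit remains unknown, so the compounds shown cannot tell whether the extra nitrogen atoms in the five-membered ring matter at all. As far as these compounds go, it is also open whether the 2-chloro-4-fluorophenyl group of compound 1 would bring compound 4 to a readable number, and how a smaller group at this place, such as an amine or a methoxy group, would behave.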